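The source may hold more compounds than are shown below. What is called first, only, known or untested is meant among the compounds shown, and "the series" means these compounds.

Measured compounds:
compound 1 `COc1cccc(-c2cc3[nH]nc(N)c3c(=O)[nH]2)c1`: 17%
compound 2 `CC(C)(C)c1cc2[nH]nc(N)c2c(=O)[nH]1`: -15%
compound 3 `Cn1nc(N)c2c(=O)[nH]c(-c3ccccn3)cc21`: 17%

In an assay on isolated protein for inhibition of serine/threonine-protein kinase D2 (Homo sapiens), read by mobility shift assay, tested at 30 uM (a higher number here means more inhibition at the concentration tested (going by the name of the read-out), a lower number less inhibition), compound 1 gives 17%, level with compound 3 at 17%; the two sit together at the top of the three numbers and within the scatter of each other, so neither is placed ahead. Compound 2, at -15%, lies well below compound 1, a gap beyond the scatter. Compound 4 `COc1cccc(-c2cc3c(c(N)nn3C)c(=O)[nH]2)c1` has not yet been measured in this assay. It differs from compound 1 in one place: methyl in place of hydrogen on an aromatic nitrogen. Among the compounds with values here, no measured pair isolates this change. Compound 3 also carries a methyl on an aromatic nitrogen and gives 17%, within the scatter of compound 1, though compound 3 differs from compound 1 elsewhere as well. The expected step, a number 5 percentage points lower from compound 1 to compound 4 (within the scatter), is small, within the scatter or slightly downward. Compound 4 is expected to give 12%, between 0% and 25%.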

Compound 4, a percentage reported as inhibition, at one concentration (the size of the read-out at that concentration, not a potency): 25%
The estimate for compound 4 lay 13 percentage points below the measured number; measured number inside the range.
By their numbers in this assay, from the lowest: compound 2; then compounds 1, 3 and 4 (each within the scatter of the next).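

In this assay, within the data shown here, methyl in place of hydrogen on an aromatic nitrogen gives a number 8 percentage points higher from compound 1 to compound 4 (within the scatter) and this is the first pair that isolates the change. The position therefore accepts methyl with the core of compound 1 in place, and the hydrogen on that nitrogen is not needed to keep this level of inhibition at the concentration tested. Nothing available bears on a cause for this step.

On these data alone, whether a longer chain such as ethyl or propyl on this nitrogen holds the same level remains open. Also open, as far as these compounds go, is whether methyl here behaves the same way with an amine or a carboxylic acid on the aryl ring of compound 4.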